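Solubility in a cyclic phosphate cytidine series

The source may hold more compounds than are shown below. What is called first, only, known or untested is meant among the compounds shown, and "the series" means these compounds.

Measured so far:
compound 1 `Nc1ccn([C@@H]2O[C@H](COP3(=O)OCC[C@H](c4cc(Cl)cc(Cl)c4)O3)[C@@H](O)[C@@H]2O)c(=O)n1` — 1100 ug/mL
compound 2 `Nc1ccn([C@@H]2O[C@H](COP3(=O)OCC[C@H](c4ccncc4)O3)[C@@H](O)[C@@H]2O)c(=O)n1` — 37900 ug/mL; > 200000 ug/mL (2 entries)
Two of the entries for compound 2 carry a sign and are limits of the assay, not numbers.

Going by the values given here, in a physicochemical assay for solubility, at pH 4 (a lower number here means a less soluble compound, a higher number a more soluble compound), compound 1 gives 1100 ug/mL, the only plain number in the set. Compound 2 adds one further entry without a single number. Compound 3 `Nc1ccn([C@@H]2O[C@H](COP3(=O)OCC[C@H](c4cccnc4)O3)[C@@H](O)[C@@H]2O)c(=O)n1` differs from compound 1 by pyridin-3-yl in place of 3,5-dichlorophenyl on a saturated ring carbon. Among the compounds with values here, no measured step covers this change; the nearest pointer is the several entries of compound 2 in this assay, 37900 ug/mL; > 200000 ug/mL (2 entries), whose upper entries are limits of the assay. A rise well beyond the scatter is expected, a 36-fold higher number from compound 1 to compound 3 (1.56 log units; beyond the scatter). Compound 3 is therefore estimated at 40000 ug/mL, in the range 8000 ug/mL to 200000 ug/mL.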

Compound 3, solubility: 172000 ug/mL
The estimate for compound 3 lay 4.3-fold (0.63 log units) below the measured number; low and high end bracket the measured number.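

In this assay, replacing 3,5-dichlorophenyl with pyridin-3-yl on the saturated ring carbon next to the ring oxygen gives a 160-fold higher number from compound 1 to compound 3 (2.19 log units; beyond the scatter). This position therefore tolerates a change of aryl group with a large shift in the read-out, now pinned to a single number for compound 3. The entries for compound 2 include limits of the assay: the several entries of compound 2 in this assay, 37900 ug/mL; > 200000 ug/mL (2 entries)

The loss of the two chlorine atoms and the entry of the ring nitrogen remain unseparated here. On these data alone, how an unsubstituted phenyl or a carboxylic acid on the phenyl ring would stand at this carbon remains open.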